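Compound 2 to compound 4: replacing pyrazin-2-yl

This account rests on a few compounds, and the source may have more. Where it says the series, first, only, none or still open, it means among the compounds named here.

Measured in a functional assay on MCF7 cells (Homo sapiens) for antiproliferative activity, read by CCK-8 assay, with a stated time of 24 h; a lower number here means a stronger inhibitor, a higher number a weaker inhibitor:
Compound 1 `CCN(CC)Cc1ccc2nc(NC(=O)N/N=C(\C)c3ccccn3)sc2c1`: > 40000 nM, a limit
Compound 2 `CCN(CC)Cc1ccc2nc(NC(=O)N/N=C(\C)c3cnccn3)sc2c1`: > 40000 nM, a limit
Compound 3 `C/C(=N\NC(=O)Nc1nc2ccc(CN3CCC(C)CC3)cc2s1)c1cnccn1`: 11800 nM

Compound 2 sits at the limit of > 40000 nM in this assay, at which 2 of the 3 values shown sit. Compound 4 `CCN(CC)Cc1ccc2nc(NC(=O)N/N=C(\C)c3ccc(F)cc3)sc2c1` differs from it with 4-fluorophenyl in place of pyrazin-2-yl on a carbon with a double bond to nitrogen. Going by the values given here, the only measured change at this place is a step that the two limits leave unreadable from compound 1 to compound 2. Among the compounds with values here, the one readable change, an at least 3.3-fold lower number from compound 2 to compound 3 (0.53 log units; beyond the scatter), came with 4-methylpiperidin-1-yl in place of diethylamino, and compound 4 keeps the diethylamino group. Within the data shown here, no step of readable size is therefore expected in this assay. The expected size is a number no higher from compound 2 to compound 4 (the limit leaves the size open). For compound 4 the estimated value is 40000 nM, with an expected range of 15000 nM to 100000 nM.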

Compound 4, half-maximal inhibitory concentration: 12300 nM
Estimate against measurement, compound 4: 3.3-fold (0.51 log units) above, and the stated range ends above it.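

In this assay, this position can move the read-out: 4-fluorophenyl in place of pyrazin-2-yl brings an at least 3.2-fold lower number from compound 2 to compound 4 (0.51 log units; beyond the scatter), and in place of pyridin-2-yl it brings an at least 3.2-fold lower number from compound 1 to compound 4 (0.51 log units; beyond the scatter), while the step between the pyridin-2-yl and pyrazin-2-yl compounds cannot be read. The diethylamino group stays unchanged in these steps, so a readable change does not require 4-methylpiperidin-1-yl. Compound 2 stands at a limit, leaving the full size of its step open: the limit of > 40000 nM in this assay, at which 2 of the 4 values shown sit.

The compounds shown leave open whether an unsubstituted phenyl or a 4-methoxyphenyl would serve as well as 4-fluorophenyl. They also leave open whether 4-fluorophenyl and 4-methylpiperidin-1-yl would add up in one compound.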